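The source may report more compounds than this note shows. Statements on the series, on what has been measured and on what is new or still open speak of the compounds shown alone.

Measured so far in a functional assay on HeLa cells (Homo sapiens) for antiproliferative activity, read by MTT assay, with a stated time of 24 h; a lower number here means that less compound is needed, a higher number that more compound is needed for the effect:
compound 1, `CSc1ccc(/C(=N\OCCCCN2CCCCC2)c2cccc3ccccc23)cc1`: 18000 nM
compound 2, `CSc1ccc(/C(=N\OCCCCN2CCCC2)c2cccc3ccccc23)cc1`: > 50000 nM (a limit, not a number)

Compound 2 gives only a limit in this assay, so where it stands is known merely as a bound: it sits at the limit of > 50000 nM in this assay, at which 1 of the 2 values shown sits. Within the data shown here, compound 1 differs from compound 2 in one place, and the step of an at least 2.7-fold higher number from compound 1 to compound 2 (0.44 log units; beyond the scatter) is the only measured change; it shows that exchanging the amine on a saturated chain carbon, four bonds along the chain from an oxygen, moves the number beyond the scatter. Compound 3 `CCN(CCCCO/N=C(\c1ccc(SC)cc1)c1cccc2ccccc12)Cc1ccccc1` carries the next exchange at the same place: benzyl(ethyl)amino in place of pyrrolidin-1-yl on a saturated chain carbon, four bonds along the chain from an oxygen. The step from compound 1 to compound 2 bears on this change only in showing that the amine at this place matters; it gives no direction for benzyl(ethyl)amino. Because compound 2 is at a limit, a move back to the level of compound 1 or a stay at the limit are both open. The expected step of an at least 2.0-fold lower number from compound 2 to compound 3 (0.30 log units; that floor lies within the scatter) is therefore modest and uncertain in direction. Compound 3 is estimated at 25000 nM, between 8000 nM and 80000 nM.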

Compound 3, half-maximal effective concentration: 10000 nM
Estimate against measurement, compound 3: 2.5-fold (0.40 log units) above; low and high end bracket the measured number.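

In this assay, the exchange of the amine on a saturated chain carbon, four bonds along the chain from an oxygen, now has a readable direction away from pyrrolidin-1-yl: benzyl(ethyl)amino gives an at least 5.0-fold lower number from compound 2 to compound 3 (0.69 log units; beyond the scatter). The size of that step is only a floor, and the value for compound 2 is a limit, not a number: the limit of > 50000 nM in this assay, at which 1 of the 3 values shown sits. Set against the piperidin-1-yl of compound 1, the same group gives a 1.8-fold lower number from compound 1 to compound 3 (0.26 log units; within the scatter), so compound 1 and compound 3 cannot be told apart here, and among the three amines shown, pyrrolidin-1-yl alone stands apart, even though benzyl(ethyl)amino brings in an aromatic ring and piperidin-1-yl does not.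

The compounds shown do not separate the contribution of the benzyl part from that of the ethyl part, so it remains open whether a diethylamino or a benzylamino group at this place would match compound 3. Also open, from the compounds shown here alone, is how a morpholin-4-yl group would read at the same place, and whether the order of these amines would hold on a shorter or longer chain.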